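Cyclobutyl amides of the shared core: fluoro to methoxy

The source may hold more compounds than are shown below. What is called first, only, known or untested is meant among the compounds shown, and "the series" means these compounds.

compound 1 `O=C(C1CC1)N1CCc2nc(C#Cc3ccccc3)sc2C1` — > 10000 nM
compound 2 `O=C(C1CC(F)C1)N1CCc2nc(C#Cc3ccccc3)sc2C1` — 85 nM

Among the measured compounds shown here, in an assay on HEK293 cells for positive allosteric modulation of metabotropic glutamate receptor 5 (Homo sapiens), read by FLIPR, with a stated time of 1 h (on this read-out lower numbers stand for an effect already at smaller amounts and higher numbers for an effect only at larger amounts of compound), compound 2 gives 85 nM and is the only compound of the pair with a number. For compound 1 the reported value is a limit, > 10000 nM (the limit of > 10000 nM in this assay, at which 1 of the 2 values shown sits). For the measured compounds named here, the one measured step is an at least 110-fold lower number from compound 1 to compound 2 (2.07 log units; beyond the scatter), the change being 3-fluorocyclobutyl in place of cyclopropyl on a carbonyl carbon; it bears on the ring, not on the substituent of the ring.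

Compound 3 `COC1CC(C(=O)N2CCc3nc(C#Cc4ccccc4)sc3C2)C1` differs from compound 2 in methoxy in place of fluoro on a saturated ring carbon. The cyclobutyl ring that carried the large step is kept. Going by the values given here, no measured step speaks to the substituent itself, so a step of modest size is expected, estimated as a 2.4-fold higher number from compound 2 to compound 3 (0.37 log units; beyond the scatter), towards higher numbers. Compound 3 is expected to give about 200 nM, estimated within 50 nM to 1000 nM.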

Compound 3, half-maximal effective concentration: 640 nM
Beside the measured number, compound 3's estimate is 3.2-fold (0.51 log units) below it; the range from low to high includes it.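

In this assay the substituent on the cyclobutyl ring now has a measured step of its own, with methoxy in place of fluoro on a saturated ring carbon (a 7.5-fold higher number from compound 2 to compound 3 (0.88 log units; beyond the scatter)). The cyclobutyl ring therefore does not set the number alone, although the step from the cyclopropyl amide remains large with 3-methoxycyclobutyl (an at least 15-fold lower number from compound 1 to compound 3 (1.19 log units; beyond the scatter)). The value of compound 1 is a limit and not a number, so the steps from it give bounds only: the limit of > 10000 nM in this assay, at which 1 of the 3 values shown sits.

Methoxy differs from fluoro in both heavy atoms and hydrogen-bond acceptors, and compound 2 and compound 3 alone cannot separate these differences. As far as these compounds go, how a hydroxy group, an amine or a longer chain such as ethoxy would read on this ring carbon remains open.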